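The compounds below may be only part of what the source reports. "The series", "measured", "known", "first", "only" and "open" are said of these compounds alone.

Going by the values given here, compound 1 `COc1ccc(CNC(=O)c2cc(-c3cncc(C)c3)ncc2-c2cncc(F)c2)nc1OC` is the single member of the set with a numerical result: in an assay on CHO cells for antagonist activity at Orexin/Hypocretin receptor type 1 variant I408V (Homo sapiens), read by FLIPR, with a stated time of 5 min (a higher number here means a weaker inhibitor, a lower number a stronger inhibitor), compound 1 gives 10000 nM, the only value shown as a number among the three measured. Compound 2 `COc1ccc(CNC(=O)c2nc(-c3cncc(C)c3)ncc2-c2ccccc2)nc1OC` returns a limit rather than a number in this assay, > 10000 nM; this is the limit of > 10000 nM in this assay, at which 1 of the 3 values shown sits. Compound 3 `COc1ccc(CNC(=O)c2nc(-c3cncc(C)c3)cnc2-c2ccccc2)nc1OC` likewise returns a limit, > 20000 nM; this is the limit of > 20000 nM in this assay, at which 1 of the 3 values shown sits. Compound 1 therefore stands as the sole placed point, and at a weak level. Among the compounds with values here, no step between measured compounds that differ in one place is available, so compounds 2 and 3 show only that each sits at a limit. Compound 4 `COc1ccc(CNC(=O)c2cc(-c3cncc(C)c3)ncc2-c2ccccc2F)nc1OC` is the unmeasured partner of compound 1; the change is 2-fluorophenyl in place of 5-fluoropyridin-3-yl on an aromatic carbon. Within the data shown here, with no comparable step to lean on, the expected step is a 1.4-fold lower number from compound 1 to compound 4 (0.15 log units; within the scatter), not clearly beyond the scatter in either direction. Compound 4 is accordingly estimated at 7000 nM in this assay, with a range from 2500 nM to 20000 nM.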

Compound 4, half-maximal inhibitory concentration: 3000 nM
Compound 4: the middle estimate sits 2.3-fold (0.37 log units) above what was measured; low and high end bracket the measured number.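

In this assay, going by these compounds alone, the replacement of 5-fluoropyridin-3-yl by 2-fluorophenyl gives the only readable step: a 3.3-fold lower number from compound 1 to compound 4 (0.52 log units; beyond the scatter). This shows that the position, on an aromatic carbon ortho to a large group, responds to the group it carries, which compounds 2 and 3 could not show, as both stand at limits. The change removes the nitrogen of the outgoing ring and moves the fluorine in one step, and no measurement shown accounts for the difference.

From the compounds shown here alone, whether the step follows the loss of that ring nitrogen or the new place of the fluorine remains open. A 3-fluorophenyl and a 2-chlorophenyl at this position would help to separate the two readings, and how far the number can fall below that of compound 4 at 3000 nM is also unsettled.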